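The compounds below may be only part of what the source reports. "The series", "measured", "known", "first", "only" and "open" are said of these compounds alone.

Compound 1 `Cc1cc(C)cc(Cn2c(=O)[nH]c3ccc(Cl)cc32)c1` gives 8900 nM in an ADME assay on MT4 cells (Homo sapiens) for cytotoxicity; a lower number here means that less compound is tolerated, a higher number that more compound is tolerated. For the measured compounds named here, compound 3 `Cc1cc(C)cc(Cn2c(=O)[nH]c3cc(F)c(Cl)cc32)c1` reaches only a limit of the assay, > 410000 nM, and is the one value that sits at the limit of > 410000 nM in this assay, at which 1 of the 3 values shown sits. The change between them, (fluoro in place of hydrogen on an aromatic carbon), gives an at least 46-fold higher number from compound 1 to compound 3 (1.66 log units; beyond the scatter).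

Compound 2 `Cc1cc(C)cc(S(=O)(=O)n2c(=O)[nH]c3ccc(Cl)cc32)c1` gives 39000 nM in this assay, the highest of the two numbers, the difference between its core and that of compound 1 not being broken down here.

Compound 4 `Cc1cc(C)cc(S(=O)(=O)n2c(=O)[nH]c3cc(F)c(Cl)cc32)c1` is not yet measured in this assay. It carries the same change against compound 2, (fluoro in place of hydrogen on an aromatic carbon), as compound 3 does against compound 1. The measured step, an at least 46-fold higher number from compound 1 to compound 3 (1.66 log units; beyond the scatter), is the basis for the expectation. A comparable step is expected for compound 4, a 13-fold higher number from compound 2 to compound 4 (1.11 log units; beyond the scatter), which would very likely place compound 4 at the limit as well. The expected reading for compound 4 is 500000 nM, in the range 150000 nM to 1500000 nM.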

Compound 4, half-maximal cytotoxic concentration: 140000 nM
The estimate for compound 4 lay 3.6-fold (0.55 log units) above the measured number; the whole stated range lies above it.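

In this assay, fluoro in place of hydrogen on an aromatic carbon again gives a higher number, a 3.6-fold higher number from compound 2 to compound 4 (0.56 log units; beyond the scatter), so the direction of the change carries over to the core of compound 2, but its size does not: the same change on two cores in this assay, an at least 46-fold higher number (1.66 log units; beyond the scatter) from compound 1 to compound 3 and a 3.6-fold higher number (0.56 log units; beyond the scatter) from compound 2 to compound 4, at least 12-fold (1.10 log units) apart, beyond the scatter of two such steps. Compound 3 stands at a limit of the assay, > 410000 nM, and not at a number. Two cores show neither why the steps differ nor what size the step would take on a third core.

Open, on these data alone, is whether methoxy or a nitrile on the same aromatic carbon would also give steps that differ between the two cores. Also open, as far as these compounds go, is how an amine in place of the chloro group would read.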